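The compounds below may be only part of what the source reports. "The series", "measured", "known", "first", "only" and "open" are said of these compounds alone.

Measured so far:
compound 1 `CNS(=O)(=O)Nc1cccc(Cc2c(C)c3ccc(Oc4ncccn4)cc3oc2=O)c1`: 101000 ng.h/mL
compound 2 `CNS(=O)(=O)Nc1cccc(Cc2c(C)c3ccc(Oc4nccs4)cc3oc2=O)c1`: 86900 ng.h/mL

In an ADME assay on the whole organism (plasma, strain BALB) for pharmacokinetics, with Mus musculus as the target, read by LC-MS, with a stated time of 24 h, at a dose of 100 mg/kg by the oral route (a higher number here means more compound in the circulation at the dose given, a lower number less compound in the circulation), compound 2 stands at 86900 ng.h/mL, within the scatter of compound 1: a 1.2-fold lower number from compound 1 to compound 2 (0.07 log units; within the scatter). Compound 3 `CNS(=O)(=O)Nc1cccc(Cc2c(C)c3ccc(Oc4nccs4)cc3oc2=O)c1F` differs from compound 2 by one change: fluoro in place of hydrogen on an aromatic carbon, ortho to a (methylsulfamoyl)amino group. Among the measured compounds shown here, the one measured step concerns the group on an oxygen on an aromatic ring, so it bears on this change only indirectly. For the measured compounds named here, no measured pair shows fluoro in place of hydrogen. The data therefore indicate no direction, and no step beyond the scatter is expected in this assay. The expected size is a 1.0-fold higher number from compound 2 to compound 3 (0.02 log units; within the scatter). Compound 3 is expected at 90000 ng.h/mL, with an estimated range from 35000 ng.h/mL to 230000 ng.h/mL.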

Compound 3, area under the concentration-time curve: 174000 ng.h/mL
For compound 3 the middle estimate is 1.9-fold (0.29 log units) below the measured one; the measured number falls inside the stated range.
By their numbers in this assay, from the lowest: compounds 2, 1 and 3 (each within the scatter of the next).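

In this assay the aromatic carbon ortho to a (methylsulfamoyl)amino group now has a measured step of its own, for fluoro in place of hydrogen (a 2.0-fold higher number from compound 2 to compound 3 (0.30 log units; within the scatter)). Among the compounds shown here, the earlier step concerned only the group on an oxygen on an aromatic ring, so this pair is the first reading at this place, and the single added fluorine leaves the number within the scatter. No measurement is available here that bears on this result.

Still open, going by these compounds, is whether chloro, methyl or methoxy on this same carbon would also stay within the scatter. Also open, on these data alone, is whether fluoro in place of hydrogen gives a similar step when pyrimidin-2-yl, rather than 1,3-thiazol-2-yl, stands on the oxygen.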